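Aryl variation in a histamine agonist series: from compound 3 to 4

The source may report more compounds than this note shows. Statements on the series, on what has been measured and on what is new or still open speak of the compounds shown alone.

Measured so far:
compound 1, `Cc1nc(N)sc1CCCN/C(N)=N/C(=O)NC(C)c1cccc(F)c1`: 0.85
compound 2, `CCCCCNC(=O)/N=C(\N)NCCCc1sc(N)nc1C`: 0.78
compound 3, `Cc1ccc(C(C)NC(=O)/N=C(\N)NCCCc2sc(N)nc2C)cc1`: 0.85

In a functional assay on Right cardiac atrium for agonist activity at histamine H2 receptor (Cavia porcellus), with a stated time of 30 min, in the presence of a further agent that is not named here (a higher number here means a larger maximal response, a lower number a smaller maximal response), compound 3 gives 0.85, level with compound 1 at the digits shown. Compound 2 gives a number within the usual scatter of both. Among the compounds with values here, the only step between two measured compounds that differ in one place is no change at the digits printed from compound 1 to compound 3 (within the scatter), where a change of aromatic ring on the same chain carbon left the maximal response where it was.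

Compound 4, `Cc1nc(N)sc1CCCN/C(N)=N/C(=O)NC(C)c1cccs1`, is not yet measured. It differs from compound 3 by thiophen-2-yl in place of 4-methylphenyl on a saturated chain carbon bound to an amide-type nitrogen and a saturated chain carbon. Within the data shown here, the one step that bears on this, from compound 1 to compound 3, was a change of one aromatic ring for another at this same place and produced no shift beyond the scatter; the pentyl chain of compound 2 likewise sits within the scatter. It is therefore expected that the step a number 0.020 lower from compound 3 to compound 4 (within the scatter) stays within the scatter. Compound 4 is estimated at 0.83, in the range 0.7 to 0.95.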

Compound 4, intrinsic activity: the largest response reached, as a fraction of the reference agonist's: 0.88
The estimate for compound 4 lay 0.050 below the measured number, within the range that was stated.
By their numbers in this assay, from the lowest: compounds 2, 1, 3 and 4 (each within the scatter of the next).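

In this assay, thiophen-2-yl in place of 4-methylphenyl gives a number 0.030 higher from compound 3 to compound 4 (within the scatter), and in place of 3-fluorophenyl it gives a number 0.030 higher from compound 1 to compound 4 (within the scatter). The place on a saturated chain carbon bound to an amide-type nitrogen and a saturated chain carbon, until now shown only with six-membered aromatic rings of carbon only, therefore also accepts a five-membered aromatic ring with 1 hetero atom without a shift beyond the scatter. The whole 1-(thiophen-2-yl)ethyl group in place of pentyl gives a number 0.10 higher from compound 2 to compound 4 (within the scatter), so that change too stays within the scatter, and no supporting data bear on this result. As far as these compounds go, whether the maximal response would hold with a carboxylic acid or an amine in place of the aromatic ring at this place stays open. A longer chain in place of pentyl also remains untested among the compounds shown.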